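The source may hold more compounds than are shown below. What is called first, only, known or untested is meant among the compounds shown, and "the series" means these compounds.

Measured compounds in an ADME assay on HepG2 cells (Homo sapiens) for cytotoxicity, read by trypan blue exclusion, with a stated time of 48 h, in the presence of a further agent that is not named here; a higher number here means that more compound is tolerated, a lower number that less compound is tolerated:
- compound 1 `c1ccc(Cn2cnc3c(-c4ccco4)nccc32)cc1`, which gives > 25000 nM; this is a limit of the assay, not a number
- compound 2 `COc1ccc2nc(C)cc(OCC(=O)Nc3ccccc3)c2c1`, which gives > 155000 nM; this too is a limit, not a number
- compound 3 `COc1ccccc1NC(=O)COc1cc(C)nc2ccc(C(F)(F)F)cc12`, which gives > 128000 nM; again a limit, not a number

Compound 2 therefore has no measured number in this assay, only a limit, as described by the limit of > 155000 nM in this assay, at which 1 of the 3 values shown sits. Going by the values given here, the two other compounds also end at limits, so no ranking among the three is possible, and no step between compounds that differ in a single place is available.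

Compound 4 `COc1ccc2nc(C)cc(OCC(=O)Nc3ccc(Cl)cc3)c2c1` is not yet measured. It differs from compound 2 by chloro in place of hydrogen on an aromatic carbon. Without a measured step to lean on, the expectation rests only on the fact that compound 2 sits at a limit, > 155000 nM, which itself gives no number to move from. The step of an at least 1.0-fold lower number from compound 2 to compound 4 (0.01 log units; that floor lies within the scatter) is expected to be none beyond the scatter, with the result most likely again reported as a limit. Compound 4 is accordingly estimated at 150000 nM, within a range from 40000 nM to 300000 nM.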

Compound 4, half-maximal cytotoxic concentration: 89900 nM
Beside the measured number, compound 4's estimate is 1.7-fold (0.22 log units) above it; the measured number falls inside the stated range.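

In this assay compound 4 gives 89900 nM, which makes it the only compound shown that ends at a real number rather than a limit, so this series now has one value that other changes could be read against. Swapping phenyl for 4-chlorophenyl, with the chloro on a six-membered aromatic ring of carbon only and para to a large group, gives an at least 1.7-fold lower number from compound 2 to compound 4 (0.23 log units; that floor lies within the scatter), so the true step may be that small or larger, and only its floor is known. The size of the step stays open because compound 2 ends at a limit, not a number: the limit of > 155000 nM in this assay, at which 1 of the 4 values shown sits.

Compound 1 and compound 3 also end at limits and differ from compound 4 in more than one place, so they say nothing about what the chloro does here. Going by these compounds, how a fluoro, a bromo, an amine or a carboxylic acid at this same place would compare with the chloro in this assay also remains open.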